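Aryl Exchange at the Saturated Ring Carbon of the Core

A few compounds are considered here, and "the series" means these few. Any claim that something is new, unique, unknown or untested is made for them only; others in the source may bear on it.

compound 1, `Cc1ccc(C2C(C#N)=C(N)N(c3ccc(S(N)(=O)=O)cc3)C3=C2CCCC3)cc1`: 90%
compound 2, `COc1ccc(C2C(C#N)=C(N)N(c3ccc(S(N)(=O)=O)cc3)C3=C2CCCC3)cc1`: 100%

In a functional assay on Ehrlich cells (Mus musculus) for cytotoxicity, read by trypan blue exclusion, with a stated time of 2 h, tested at 100 ug/mL (on this read-out higher numbers stand for a stronger effect at the one concentration tested and lower numbers for a weaker effect), compound 2 gives 100%. Compound 1 gives 90% in the same assay, and the two numbers lie within the scatter of each other, so no ranking of compound 2 against compound 1 follows from them. Within the data shown here, the single measured step, a number 10 percentage points higher from compound 1 to compound 2 (within the scatter), concerns the aryl ring on the saturated ring carbon of the shared core, the same place that the present change touches.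

Compound 3, `N#CC1=C(N)N(c2ccc(S(N)(=O)=O)cc2)C2=C(CCCC2)C1c1ccccc1Cl`, differs from compound 2 as follows: 2-chlorophenyl in place of 4-methoxyphenyl on a saturated ring carbon. Among the measured compounds shown here, the one step that bears on this exchange, a number 10 percentage points higher from compound 1 to compound 2 (within the scatter), stayed within the scatter, and nothing shows that a different aryl ring at this carbon moves the read-out of this assay beyond it. A step of no size beyond the scatter is therefore expected here, with the estimated change from compound 2 to compound 3 being a number 10 percentage points lower from compound 2 to compound 3 (within the scatter).

Compound 3 is estimated at 90%, expected to fall between 70% and 100%.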

Compound 3, a percentage reported as activity, at one concentration (the size of the read-out at that concentration, not a potency): 10%
The estimate for compound 3 lay 80 percentage points above the measured number; measured number below the stated range.
By their numbers in this assay, from the lowest: compound 3; then compounds 1 and 2 (each within the scatter of the next).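

In this assay, the aryl ring on the saturated ring carbon of the shared core proves to be a position where the read-out can change strongly: the exchange for 2-chlorophenyl gives a number 90 percentage points lower from compound 2 to compound 3 (beyond the scatter), and the same exchange starting from 4-methylphenyl gives a number 80 percentage points lower from compound 1 to compound 3 (beyond the scatter). The two starting compounds lie within the scatter of each other, so the large drop appears from either one, and the earlier step between them gave no sign of it. The data shown offer no measurement that would account for this drop.

The 2-chlorophenyl group differs from the 4-methoxyphenyl and 4-methylphenyl groups both in its substituent and in that substituent's place on the phenyl ring, so these compounds cannot separate the two changes, and a 4-chlorophenyl or a 2-methoxyphenyl group at the same carbon would be needed to do so. From the compounds shown here alone, it also remains open whether a plain phenyl group at this carbon would read like compound 2 or like compound 3, and, with a single concentration behind each number, how the compounds compare in potency.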